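Two Limits and a Methoxy Swap on the Benzyl Amide

This account rests on a few compounds, and the source may have more. Where it says the series, first, only, none or still open, it means among the compounds named here.

Compound 1 `Cc1cc(C)cc(C(=O)N(CCCCCC(=O)Nc2ccccc2N)CC(=O)NC2CCCCC2)c1` and compound 2 `Cc1cc(C)cc(CNC(=O)CN(CCCCCC(=O)Nc2ccccc2N)C(=O)c2cc(C)cc(C)c2)c1` share a core and differ in a step that the two limits leave unreadable from compound 1 to compound 2, a step that remains unreadable because of the limit of > 10000 nM in this assay, at which 2 of the 2 values shown sit. In an assay on Sf9 cells for inhibition of protein deacetylase HDAC6 (Homo sapiens), read by fluorescence, with a stated time of 90 min (on this read-out higher numbers stand for weaker inhibition and lower numbers for stronger inhibition), compound 1 gives > 10000 nM, a limit of the assay and not a number. In this assay compound 2 likewise gives > 10000 nM, again a limit. Compound 3 `COc1ccc(CNC(=O)CN(CCCCCC(=O)Nc2ccccc2N)C(=O)c2cc(C)cc(C)c2)cc1` carries 4-methoxyphenyl in place of 3,5-dimethylphenyl on a saturated chain carbon bound to an amide-type nitrogen. No measured step sizes this change, and both anchors sit at the limit, so compound 3 is expected at 15000 nM (range 5000 nM to 50000 nM). The estimated step that the limit leaves unreadable from compound 2 to compound 3 is expected to stay within the scatter.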

Compound 3, half-maximal inhibitory concentration: > 10000 nM
Compound 3 ended at the assay's limit; the forecaster's own chance of this, stated with the estimate: 80%; the middle value lies beyond the limit too.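

No new step can be read among compound 1, compound 2 and compound 3, because all three stop at the same limit: the limit of > 10000 nM in this assay, at which 3 of the 3 values shown sit. On these data alone, whether the cyclohexyl, 3,5-dimethylbenzyl or 4-methoxybenzyl group changes inhibition at all stays open.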